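The source may hold more compounds than are shown below. What is called first, only, known or untested is meant among the compounds shown, and "the series" means these compounds.

Two quinone compounds were measured for cytotoxicity. Compound 1, `O=C(OC1=CC(=O)c2ccccc2C1=O)c1ccccc1`, gives in a functional assay on HeLa cells (Homo sapiens) for cytotoxicity (on this read-out higher numbers stand for weaker inhibition and lower numbers for stronger inhibition), a value of 55000 nM. Compound 2, `COc1ccc2c(c1)C(=O)C=CC2=O`, gives in this assay a value of 22700 nM. Of the two numbers, that of compound 2 is the lower one; the gap between it and the higher number of compound 1 lies beyond the usual scatter of repeated measurements, so compound 2 stands as the stronger of the two in this assay.

The next compound, compound 3, `CCOc1ccc2c(c1)C(=O)C=CC2=O`, has not yet been measured. It differs from compound 2 by methyl in place of hydrogen on a saturated chain carbon bound to an oxygen on an aromatic ring. For the measured compounds named here, no measured pair shows the effect of this kind of change, so the size of the step can only be estimated. The change adds a single carbon at a chain position away from the core of compound 2, and nothing in the two measured values points to a large move in either direction; a step in this assay no larger than the scatter is expected.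

Compound 3 is therefore estimated to give 25000 nM, with a range from 10000 nM to 60000 nM, which means an expected step of a 1.1-fold higher number from compound 2 to compound 3 (0.04 log units; within the scatter).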

Compound 3, half-maximal inhibitory concentration: 25100 nM
The estimate for compound 3 lay 1.0-fold (0.00 log units) below the measured number, and the stated range covers the measured number.
By their numbers in this assay, from the lowest: compounds 2 and 3 (each within the scatter of the next); then compound 1.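

In this assay, going from methoxy to ethoxy, with methyl in place of hydrogen on a saturated chain carbon bound to an oxygen on an aromatic ring, gives a 1.1-fold higher number from compound 2 to compound 3 (0.04 log units; within the scatter). For the compounds shown here, this is the first step that can be read between two compounds differing in one place, and it puts a first measured size on a change at this position. At this position, then, one added carbon leaves compound 2 and compound 3 within the scatter of each other, although this single pair cannot show how far that holds. No accompanying measurement bears on this result.

What the compounds shown leave open is whether the position tolerates more than one added carbon, as a longer chain such as propoxy or a branched one such as isopropoxy would test. They also do not show how this assay would respond to an amine or a carboxylic acid at the end of the chain, where the group entering would no longer be a plain methyl.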